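Cyano in Place of Isopropoxy: Expecting Compound 3

A few compounds are considered here, and "the series" means these few. Any claim that something is new, unique, unknown or untested is made for them only; others in the source may bear on it.

Measured compounds:
Compound 1, `Cc1cc(Sc2cccc(Cl)c2)c(S(C)(=O)=O)cc1C(=O)N=C(N)N`: 37 nM
Compound 2, `Cc1cc(OC(C)C)c(S(C)(=O)=O)cc1C(=O)N=C(N)N`: 19 nM

Both compounds were tested in a functional assay for inhibition of sodium/hydrogen exchanger (Oryctolagus cuniculus); on this read-out higher numbers stand for weaker inhibition and lower numbers for stronger inhibition. For the measured compounds named here, compound 2 gives the lowest of the two numbers seen so far, and its nearest neighbour is compound 1; the step of a 1.9-fold lower number from compound 1 to compound 2 (0.29 log units; within the scatter) is the only measured step, and it stays within the scatter, so the two compounds cannot be ranked against each other.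

Compound 3, `Cc1cc(C#N)c(S(C)(=O)=O)cc1C(=O)N=C(N)N`, has not yet been measured. It differs from compound 2 in one place: cyano in place of isopropoxy on an aromatic carbon. Going by the values given here, the single measured step changed the group at the same aromatic carbon, and replacing (3-chlorophenyl)sulfanyl with isopropoxy moved the number only within the scatter. Among the compounds with values here, no measured step shows a cyano group anywhere, so the direction of the change is uncertain, and the most defensible expectation is a step within the scatter.

Compound 3 is therefore expected to give 35 nM, with a range from 12 nM to 110 nM. That estimate means a 1.8-fold higher number from compound 2 to compound 3 (0.27 log units; within the scatter), a step expected not to exceed the usual scatter.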

Compound 3, half-maximal inhibitory concentration: 70 nM
Beside the measured number, compound 3's estimate is 2.0-fold (0.30 log units) below it, and the stated range covers the measured number.
By their numbers in this assay, from the lowest: compounds 2, 1 and 3 (each within the scatter of the next, the first and the last beyond it).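

In this assay, for the compounds shown here, cyano in place of isopropoxy on this aromatic carbon gives a 3.7-fold higher number from compound 2 to compound 3 (0.57 log units; beyond the scatter), and this is the first step at the position to go beyond the scatter, which shows that the group held here can change the read-out. Set against (3-chlorophenyl)sulfanyl, cyano gives a 1.9-fold higher number from compound 1 to compound 3 (0.28 log units; within the scatter), so that pair cannot be ranked, and only compound 2 and compound 3 are separated, with compound 1 unresolved from either of them. Nothing available accounts for the difference between isopropoxy, with 4 heavy atoms, and cyano, with 2 heavy atoms.

Going by these compounds alone, with only three groups compared at this carbon, it remains open whether a methoxy group, an ethoxy group or a simple amine would give a number closer to that of compound 2 or to that of compound 3, and so whether the oxygen link, the chain or something else matters here. From the compounds shown here alone, it is also open whether the step from isopropoxy to cyano would keep its size if the methyl or methylsulfonyl group on the shared core were replaced by another group.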